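A Hydroxyphenyl Replaces a Cyanophenyl at the Saturated Ring Carbon

The source may report more compounds than this note shows. Statements on the series, on what has been measured and on what is new or still open speak of the compounds shown alone.

Compound 1 `Cc1cccc(NC(=O)CN2CCC(c3ccccc3C#N)CC2)c1` was tested in a functional assay on HEK293 cells for agonist activity at D(4) dopamine receptor (Homo sapiens), read by FLIPR (a lower number here means a smaller maximal response, a higher number a larger maximal response), where compound 1 gives 71%. Two related amides share the same core: compound 2 `Cc1cc(C)cc(NC(=O)CN2CCC(c3cccc[n+]3[O-])CC2)c1`, which in this assay gives 76%, and compound 3 `Cc1cc(NC(=O)CN2CCC(c3cccc[n+]3[O-])CC2)ccc1F`, which gives 75%. All three numbers sit within the usual scatter of one another, so compound 1 is neither set apart from compound 3 nor from compound 2 on these readings. Within the data shown here, the one single-point step in the set, a number 1 percentage points lower from compound 2 to compound 3 (within the scatter), concerns the amide-type nitrogen only and leaves the saturated ring carbon untouched.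

Compound 4 `Cc1cccc(NC(=O)CN2CCC(c3ccc(O)cc3)CC2)c1` differs from compound 1 at that saturated ring carbon: 4-hydroxyphenyl in place of 2-cyanophenyl on a saturated ring carbon. No measured step touches this position, so no shown step bears directly on it; the amide-side step of a number 1 percentage points lower from compound 2 to compound 3 (within the scatter) stayed within the scatter, and nothing in the data points to a change beyond the scatter here. Compound 4 is therefore estimated to give 71% in this assay, with a range from 56% to 86%. That estimate corresponds to an expected step of no change at the digits printed from compound 1 to compound 4 (within the scatter), which is expected to lie within the scatter.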

Compound 4, largest response reached (reported as efficacy), in percent of the reference or control that the assay uses: 60%
Beside the measured number, compound 4's estimate is 11 percentage points above it; the measured number falls inside the stated range.
By their numbers in this assay, from the lowest: compound 4; then compounds 1, 3 and 2 (each within the scatter of the next).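

In this assay, putting 4-hydroxyphenyl in place of 2-cyanophenyl on the saturated ring carbon gives a number 11 percentage points lower from compound 1 to compound 4 (beyond the scatter), a modest step but the only one in this set that lies beyond the scatter. Among these compounds, the earlier compounds could not show this, since their one step concerned the amide-type nitrogen and left this carbon untouched; the maximal response is now seen to shift with a change at this position. Nothing available explains the size or direction of this step.

The change swaps the nitrile for a hydroxyl and alters where the substituent sits on the phenyl ring, so the compounds shown do not separate these two parts. From the compounds shown here alone, it also remains open how an unsubstituted phenyl or a methoxyphenyl at this carbon would compare.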